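Swapping quinolinyl for naphthyl in an oxazolidinone series

The source may hold more compounds than are shown below. What is called first, only, known or untested is meant among the compounds shown, and "the series" means these compounds.

Going by the values given here, compound 2 `O=C1OC(c2ccnc3ccccc23)CN1C1CCN(Cc2cc3ccccc3[nH]2)CC1` gives 1000 nM in an in vitro functional assay on RBL cells for antagonist activity at C-C chemokine receptor type 8 (Homo sapiens), read by FLIPR and calcium flux (on this read-out higher numbers stand for weaker inhibition and lower numbers for stronger inhibition), the highest of the two numbers known. Compound 1 `COc1ccc2nccc(C3CN(C4CCN(Cc5cc6ccccc6[nH]5)CC4)C(=O)O3)c2c1` gives 25.1 nM in this assay. Among the compounds with values here, the sole measured step, a 40-fold higher number from compound 1 to compound 2 (1.60 log units; beyond the scatter), concerns a methoxy group alone. Compound 3 `O=C1OC(c2cccc3ccccc23)CN1C1CCN(Cc2cc3ccccc3[nH]2)CC1` carries naphthalen-1-yl in place of quinolin-4-yl on a saturated ring carbon. Within the data shown here, no measured step bears on this change, so the data give no guide to its size or direction. Compound 3 is therefore expected to show a 1.5-fold higher number from compound 2 to compound 3 (0.18 log units; within the scatter), estimated as no step beyond the scatter, though with wide uncertainty. Compound 3 is estimated at 1500 nM, between 300 nM and 8000 nM.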

Compound 3, half-maximal inhibitory concentration: < 50200 nM
Compound 3 was reported as a limit; the forecaster's own chance of this, stated with the estimate: 20%; the middle value does not contradict the limit.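

Going by these compounds alone, compound 3 is reported only as the limit < 50200 nM and no step from compound 2 to compound 3 can be read from it. The compounds shown leave open whether naphthalen-1-yl in place of quinolin-4-yl changes the number at all, and in which direction.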